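Shrinking the pendant aromatic group on a shared core

The compounds below may be only part of what the source reports. "The series", "measured", "known", "first", "only" and "open" are said of these compounds alone.

Measured compounds:
- compound 1 `c1cnc2c(c1)CCC[C@@H]2N(CCCN1CCNCC1)Cc1cc2ccccc2cn1`: 17 nM
- compound 2 `c1cnc2c(c1)CN[C@H](CN(CCCN1CCNCC1)[C@H]1CCCc3cccnc31)C2`: 2640 nM
- compound 3 `c1cnc2c(c1)CCC[C@@H]2N(CCCN1CCNCC1)Cc1nc2ccccc2[nH]1`: 45 nM

In a functional assay on CCRF-CEM cells for antagonist activity at C-X-C chemokine receptor type 4 (Homo sapiens), read by calcium flux, with stated times of 25 min and 90 s (a lower number here means a stronger inhibitor, a higher number a weaker inhibitor), compound 3 stands second highest of the three numbers, close to compound 1 and far from compound 2. Compound 4 `c1cnc(CN(CCCN2CCNCC2)[C@H]2CCCc3cccnc32)nc1` differs from compound 3 by pyrimidin-2-yl in place of 1H-benzimidazol-2-yl on a saturated chain carbon bound to an amine nitrogen. Among the measured compounds shown here, no measured step removes a fused ring; the nearest guides are a 2.6-fold higher number from compound 1 to compound 3 (0.42 log units; beyond the scatter), a modest swap of one bicyclic aromatic for another, and a 59-fold lower number from compound 2 to compound 3 (1.77 log units; beyond the scatter), a large change once the attached group changes character. A loss of the second ring is therefore expected to raise the number, and compound 4 is estimated at 400 nM (range 80 nM to 2000 nM), a step of an 8.9-fold higher number from compound 3 to compound 4 (0.95 log units; beyond the scatter) in this assay.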

Compound 4, half-maximal inhibitory concentration: 4320 nM
The estimate for compound 4 lay 11-fold (1.03 log units) below the measured number; measured number outside the range, above it.
By their numbers in this assay, from the lowest: compound 1; then compound 3; then compounds 2 and 4 (each within the scatter of the next).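

In this assay, replacing the fused aromatic group with pyrimidin-2-yl costs far more than the exchange of one bicyclic aromatic for another did: a 96-fold higher number from compound 3 to compound 4 (1.98 log units; beyond the scatter) and a 250-fold higher number from compound 1 to compound 4 (2.41 log units; beyond the scatter) are both large steps. A group with one six-membered aromatic ring is therefore poorly tolerated at this place, and a 1.6-fold higher number from compound 2 to compound 4 (0.21 log units; within the scatter) leaves compound 4 unresolved from compound 2. No evidence here accounts for the loss. Going by these compounds, it remains open whether a phenyl or pyridin-2-yl group at this place would track compound 3 or compound 4.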